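The source may report more compounds than this note shows. Statements on the series, on what has been measured and on what is new or still open speak of the compounds shown alone.

Of the compounds shown here, three of one shared core have been measured so far: compound 1 `CCCc1nc(C)c2c(CC)nnc(SC)n12`, compound 2 `CCCc1nc(C)c2cnnc(SC)n12` and compound 3 `CCCc1nc(C)c2c(C)nnc(SC)n12`. In a functional assay for inhibition, with Homo sapiens as the target (a lower number here means a stronger inhibitor, a higher number a weaker inhibitor), compound 1 gives > 48000 nM, which is a limit of the assay and not a number. In this assay compound 2 gives > 48000 nM, again a limit. In this assay compound 3 gives > 48000 nM, also a limit, so compound 3 stands only at a limit, as do the two other values shown. The three steps among them, a step that the two limits leave unreadable from compound 1 to compound 2, a step that the two limits leave unreadable from compound 1 to compound 3 and a step that the two limits leave unreadable from compound 2 to compound 3, are all unreadable because of the limit of > 48000 nM in this assay, at which 3 of the 3 values shown sit.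

Compound 4 `CCCc1nnc(SC)n2c(CCC)nc(C)c12` is not yet measured. It differs from compound 3 by ethyl in place of hydrogen on a saturated chain carbon bound to an aromatic carbon. The measured step that bears most on this change is a step that the two limits leave unreadable from compound 1 to compound 3, which runs the same kind of change in reverse and whose size cannot be read. Among the compounds with values here, no step among the measured compounds therefore gives a direction or a size for this assay.

Compound 4 is expected to remain at about 60000 nM, with a range from 20000 nM to 200000 nM. The step this estimate means, a step that the limit leaves unreadable from compound 3 to compound 4, is expected to show no change beyond the scatter.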

Compound 4, half-maximal inhibitory concentration: > 48000 nM
Compound 4 ended at the assay's limit; the forecaster's own chance of this, stated with the estimate: 85%; the middle value is on the limit's open side.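

In this assay compound 4 gives > 48000 nM, a limit of the assay and not a number. Its steps to compound 1, compound 2 and compound 3 therefore cannot be read: the limit of > 48000 nM in this assay, at which 4 of the 4 values shown sit. The compounds shown leave open how strongly any of the four inhibits, and whether changing these chains on the shared core alters that.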